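This account rests on a few compounds, and the source may have more. Where it says the series, first, only, none or still open, it means among the compounds named here.

Measured compounds:
- Compound 1, `NCCCCn1cc(-c2ccc3cc[nH]c3c2)c(C(F)(F)F)n1`, in an assay on isolated protein for inhibition of Myeloperoxidase (Homo sapiens) (a higher number here means a weaker inhibitor, a lower number a stronger inhibitor), gives 330 nM.
- Compound 2, `NC(=O)CCn1cc(-c2ccc3cc[nH]c3c2)c(C(F)(F)F)n1`, in this assay gives 4200 nM.

Among the compounds with values here, compound 2 holds the highest number of these two; the only step to it is a 13-fold higher number from compound 1 to compound 2 (1.10 log units; beyond the scatter). Compound 3, `O=C(O)CCn1cc(-c2ccc3cc[nH]c3c2)c(C(F)(F)F)n1`, differs from compound 2 by hydroxy in place of amino on a carbonyl carbon. Within the data shown here, no measured step covers this change, and the only step seen, a 13-fold higher number from compound 1 to compound 2 (1.10 log units; beyond the scatter), concerns a different replacement on the same chain. Compound 3 is therefore expected to lie close to compound 2, with a modest step of a 1.4-fold higher number from compound 2 to compound 3 (0.15 log units; within the scatter) if any. Compound 3 is estimated at 6000 nM, within 2000 nM to 20000 nM.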

Compound 3, half-maximal inhibitory concentration: 5200 nM
The estimate for compound 3 lay 1.2-fold (0.06 log units) above the measured number; the measured number falls inside the stated range.
By their numbers in this assay, from the lowest: compound 1; then compounds 2 and 3 (each within the scatter of the next).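

In this assay, replacing the amino of the carbamoyl with hydroxy, which turns the 2-carbamoylethyl chain into the 2-carboxyethyl chain, gives a step that cannot be told apart from scatter (a 1.2-fold higher number from compound 2 to compound 3 (0.09 log units; within the scatter)). Carbamoyl and carboxy therefore read alike at this place, and the carboxy compound stands as clearly apart from the amine-ended chain of compound 1 as the carbamoyl compound does (a 16-fold higher number from compound 1 to compound 3 (1.20 log units; beyond the scatter)). Nothing at hand offers a reason for this pattern.

From the compounds shown here alone, whether the amine or the chain length sets compound 1 apart remains open. An amine on a chain as long as 2-carboxyethyl, or a carboxylic acid on a longer chain, would separate the two.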